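The source may report more compounds than this note shows. Statements on the series, on what has been measured and on what is new or still open speak of the compounds shown alone.

- compound 1 `Cc1ccc(NC(=O)/C=C/c2ccccc2)c(C(N)=O)c1`: 3970 nM
- compound 2 `NC(=O)c1cc(Br)ccc1NC(=O)/C=C/c1ccccc1`: 684 nM
- compound 3 `NC(=O)c1cc(I)ccc1NC(=O)/C=C/c1ccccc1`: not yet measured

Going by the values given here, in a functional assay on PC-3 cells (Homo sapiens) for inhibition, read by sulforhodamine B assay, with a stated time of 48 h (a higher number here means a weaker inhibitor of growth, a lower number a stronger inhibitor of growth), compound 2 gives 684 nM, the lower of the two numbers so far. Compound 3 differs from it at one place, with iodo in place of bromo on an aromatic carbon. Among the compounds with values here, only one measured step bears on this place: a 5.8-fold lower number from compound 1 to compound 2 (0.76 log units; beyond the scatter). That step, bromo in place of methyl, was modest but beyond the scatter. Within the data shown here, no measured compound carries iodo yet, so this single step sets no trend and offers only a weak guide to direction. A swap of bromo for iodo is therefore expected to be smaller than that step, perhaps slightly downward and probably within the scatter. The expected step is a 1.2-fold lower number from compound 2 to compound 3 (0.09 log units; within the scatter). The estimate for compound 3 is 550 nM, with an expected range from 220 nM to 1400 nM.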

Compound 3, concentration for 50% growth inhibition: 628 nM
The estimate for compound 3 lay 1.1-fold (0.06 log units) below the measured number; the measured number falls inside the stated range.
By their numbers in this assay, from the lowest: compounds 3 and 2 (each within the scatter of the next); then compound 1.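

In this assay, iodo in place of bromo on this aromatic carbon, para to a large group and meta to a carbamoyl group, gives a 1.1-fold lower number from compound 2 to compound 3 (0.04 log units; within the scatter), so the two groups cannot be told apart at this place. Iodo in place of methyl gives a 6.3-fold lower number from compound 1 to compound 3 (0.80 log units; beyond the scatter), which lies beyond the scatter, as does a 5.8-fold lower number from compound 1 to compound 2 (0.76 log units; beyond the scatter), so the lower number relative to methyl now holds for two halogens rather than one. Nothing measured here explains why bromo and iodo read alike or why both differ from methyl.

Still open, on these data alone, is how chloro, fluoro or a group without a halogen, such as methoxy, an amine or a carboxylic acid, would behave at this place. As far as these compounds go, the shared core is unchanged throughout, so how changes elsewhere would combine with bromo or iodo also remains unknown.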